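Branching the Side Chain of Compound 1

The compounds below may be only part of what the source reports. "The series", "measured", "known", "first", "only" and "open" are said of these compounds alone.

Measured in a functional assay on SW1573 cells (Homo sapiens) for antiproliferative activity, read by sulforhodamine B assay, with a stated time of 48 h; on this read-out higher numbers stand for weaker inhibition of growth and lower numbers for stronger inhibition of growth:
compound 1 `CCCCCC(C#CC(=O)OC)O/C=C/C(=O)OC`: 1700 nM
compound 2 `CC1CCC(C(C)C)C(OC(=O)C#CC(O/C=C/C(=O)OC2CC(C)CCC2C(C)C)C(C)C)C1`: > 100000 nM, a limit
compound 3 `COC(=O)C#CC(CC(C)C)O/C=C/C(=O)OC`: 380 nM

Only compound 1 and compound 3 give actual numbers, and compound 1 has the higher of the two. Compound 2 reports only a limit. Compound 4 `CCC(C)C(C#CC(=O)OC)O/C=C/C(=O)OC` departs from compound 1 in one place: sec-butyl in place of pentyl on a saturated chain carbon bound to an oxygen on an unsaturated carbon and a triple-bonded carbon. The nearest measured guide is a 4.5-fold lower number from compound 1 to compound 3 (0.65 log units; beyond the scatter). That step also brings in a branched chain, but it lies at a different chain carbon, so it is only a partial guide. A smaller step in the same direction is therefore expected in this assay, towards a lower number. The expected change is a 2.4-fold lower number from compound 1 to compound 4 (0.39 log units; beyond the scatter). For compound 4 the estimated value is 700 nM, with an expected range of 200 nM to 2400 nM.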

Compound 4, concentration for 50% growth inhibition: 910 nM
Estimate against measurement, compound 4: 1.3-fold (0.11 log units) below; low and high end bracket the measured number.
By their numbers in this assay, from the lowest: compound 3; then compounds 4 and 1 (each within the scatter of the next). At a limit, above all of these: compound 2.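

In this assay, sec-butyl in place of pentyl on this saturated chain carbon gives a 1.9-fold lower number from compound 1 to compound 4 (0.27 log units; within the scatter) and so does not clearly separate the two compounds. The two branched chains do differ, with sec-butyl in place of isobutyl giving a 2.4-fold higher number from compound 3 to compound 4 (0.38 log units; beyond the scatter), so among these compounds, the presence of a branch alone does not set the number. Nothing measured here accounts for that difference. The compounds shown leave open how a phenyl ring or a longer branched chain on this carbon would compare, and whether an amine on the chain would be tolerated.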